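This account rests on a few compounds, and the source may have more. Where it says the series, first, only, none or still open, it means among the compounds named here.

Measured so far in a functional assay on MCF7 cells (Homo sapiens) for antiproliferative activity, read by sulforhodamine B assay, with a stated time of 48 h; a higher number here means a weaker inhibitor, a lower number a stronger inhibitor:
Compound 1 `Cc1ccc(NS(=O)(=O)c2ccc(N3CCNC3=O)cc2)cc1`: 610 nM
Compound 2 `O=C1NCCN1c1ccc(S(=O)(=O)Nc2ccc(I)cc2)cc1`: 600 nM
Compound 3 `CCc1ccc(NS(=O)(=O)c2ccc(N3CCNC3=O)cc2)cc1`: 810 nM

These three share one core and differ only in a single group on an aromatic carbon. Compound 3, at 810 nM, lies within the scatter of compound 1 and compound 2, so no order can be drawn among the three. The next compound is compound 4 `CC(C)(C)c1ccc(NS(=O)(=O)c2ccc(N3CCNC3=O)cc2)cc1`, which has tert-butyl in place of ethyl on an aromatic carbon.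

For the measured compounds named here, three measured steps bear on this change, all at that same place: a 1.0-fold lower number from compound 1 to compound 2 (0.01 log units; within the scatter), a 1.3-fold higher number from compound 1 to compound 3 (0.12 log units; within the scatter) and a 1.4-fold higher number from compound 2 to compound 3 (0.13 log units; within the scatter). Swapping methyl, ethyl and iodo therefore produced no step beyond the scatter. Going by the values given here, no measured compound carries a branched group such as tert-butyl, so the expectation is an extrapolation and the range is kept wide. The expected change is no step beyond the scatter, and the estimated step is a 1.0-fold higher number from compound 3 to compound 4 (0.02 log units; within the scatter). Compound 4 is estimated at 850 nM, with an expected range of 350 nM to 2000 nM.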

Compound 4, half-maximal inhibitory concentration: > 1000 nM
Compound 4 ended at the assay's limit; the forecaster's own chance of this, stated with the estimate: 3%; middle value at least 1.1-fold (0.07 log units) away from the limit.
By their numbers in this assay, from the lowest: compounds 2, 1 and 3 (each within the scatter of the next). At a limit, above all of these: compound 4.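

In this assay, for the compounds shown here, compound 4 gives no number, only a limit, the one such value: the limit of > 1000 nM in this assay, at which 1 of the 4 values shown sits. Three steps are printed for compound 4, each only a floor: an at least 1.2-fold higher number from compound 3 to compound 4 (0.09 log units; that floor lies within the scatter), an at least 1.6-fold higher number from compound 2 to compound 4 (0.22 log units; that floor lies within the scatter) and an at least 1.6-fold higher number from compound 1 to compound 4 (0.21 log units; that floor lies within the scatter). Methyl, ethyl and iodo at this place gave no step beyond the scatter, and tert-butyl is the first group whose true number stays unknown, so it could lie close to the others or far from them, and these floors alone cannot show a real loss.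

A straight butyl chain, with the same count of carbon as tert-butyl, could show whether branching or carbon count matters here. From the compounds shown here alone, how an amine or a carboxylic acid at this place would compare also stays open.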